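Flipping One Stereocentre in a Rapidly Cleared Compound

A few compounds are considered here, and "the series" means these few. Any claim that something is new, unique, unknown or untested is made for them only; others in the source may bear on it.

- compound 1 `OC(c1ccccn1)C1(c2ccccc2OC(F)(F)F)CCC1` gives 1830 mL/min/kg
- compound 2 `O[C@]1(c2ccccn2)CC[C@@H](c2ccc(C(F)(F)F)cc2)C1` gives 7670 mL/min/kg

In an ADME assay on liver for metabolic stability, with Liver microsome (Rattus norvegicus) as the target, read by LC-MS, using microsomes, with a stated time of 5 h (a higher number here means faster removal of the compound, a lower number slower removal), compound 2 stands highest of the two at 7670 mL/min/kg, and compound 1 gives 1830 mL/min/kg. The gap between these two numbers lies beyond the scatter. Compound 3 `O[C@]1(c2ccccn2)CC[C@H](c2ccc(C(F)(F)F)cc2)C1` is the next compound to consider, and the change from compound 2 is small: the two compounds have the same atoms and bonds and differ only in configuration as drawn: 1 of 2 stereo elements differ; a stereocentre at a saturated ring carbon is drawn R in compound 2 and S in compound 3. Going by the values given here, no measured pair yet shows what such a change does in this assay, so no step beyond the scatter is expected, and this expectation is only a cautious one. The expected step is a 1.3-fold lower number from compound 2 to compound 3 (0.11 log units; within the scatter). Compound 3 is estimated at 6000 mL/min/kg, with an expected range from 2500 mL/min/kg to 14000 mL/min/kg.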

Compound 3, clearance: 1430 mL/min/kg
Beside the measured number, compound 3's estimate is 4.2-fold (0.62 log units) above it; the whole stated range lies above it.
By their numbers in this assay, from the lowest: compounds 3 and 1 (each within the scatter of the next); then compound 2.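

Compound 1 and compound 2 differ in more than one place, so their gap could not show what a single stereocentre does. In this assay, changing the saturated ring carbon from R to S gives a 5.4-fold lower number from compound 2 to compound 3 (0.73 log units; beyond the scatter). This step can be attributed to configuration alone because of one fact: the fact that compounds 2 and 3 differ only in the configuration as drawn

Going by these compounds, the effect of changing the other stereocentre remains open. So does whether an amine in place of the hydroxyl would keep compound 3's slower removal.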